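This account rests on a few compounds, and the source may have more. Where it says the series, first, only, none or still open, it means among the compounds named here.

Compound 1 `C=CC1=C(C(=O)NC2CCCCC2)C(c2ccc(OC)cc2)OC1` carries a cyclohexyl on an amide-type nitrogen, and in a functional assay on HeLa cells (Homo sapiens) for cytotoxicity, read by MTT assay, with a stated time of 24 h (a higher number here means a weaker inhibitor, a lower number a stronger inhibitor), compound 1 gives 24800 nM. Compound 2 `C=CC1=C(C(=O)NCc2ccc(Cl)cc2)C(c2ccc(OC)cc2)OC1` has a 4-chlorobenzyl there instead. In this assay, as far as these compounds go, compound 2 reaches only a limit of the assay, > 100000 nM, so its true number is unknown. The measured step of an at least 4.0-fold higher number from compound 1 to compound 2 (0.60 log units; beyond the scatter) thus rests on (the limit of > 100000 nM in this assay, at which 1 of the 2 values shown sits). Compound 3 `C=CC1=C(C(=O)Nc2ccccc2OC)C(c2ccc(OC)cc2)OC1` differs from compound 2 as follows: 2-methoxyphenyl in place of 4-chlorobenzyl on an amide-type nitrogen. Among the measured compounds shown here, no measured step covers this swap, and the one known step sits at a limit, giving little guidance. The expected change an at least 1.4-fold lower number from compound 2 to compound 3 (0.15 log units; that floor lies within the scatter) is therefore uncertain. Compound 3 is expected to give about 70000 nM, likely between 20000 nM and 300000 nM, with a real chance of another limit.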

Compound 3, half-maximal inhibitory concentration: > 100000 nM
Compound 3 ended at the assay's limit (the forecaster's own chance of this, stated with the estimate: 55%); middle value at least 1.4-fold (0.15 log units) from the limit.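

Swapping the cyclohexyl on the amide-type nitrogen for 2-methoxyphenyl gives an at least 4.0-fold higher number from compound 1 to compound 3 (0.60 log units; beyond the scatter). With this second group, which carries an oxygen rather than a chlorine, the aromatic ring again gives no readable number in this assay; of these three compounds, only compound 1, with its cyclohexyl, has a value that is not a limit. The step between the two limits cannot be read, so compounds 2 and 3 cannot be ranked: the limit of > 100000 nM in this assay, at which 2 of the 3 values shown sit.

Still open, as far as these compounds go, is whether other non-aromatic groups on this nitrogen, such as cyclopentyl or tert-butyl, would give a readable value. A plain phenyl would also show whether any aromatic ring here stays at the limit.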